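The source may report more compounds than this note shows. Statements on the series, on what has been measured and on what is new or still open speak of the compounds shown alone.

Compound 2 `Oc1ccc(/C=N\NC(=S)NC2CCCCC2)cc1` gives, in a functional assay on MDA-MB-231 cells (Homo sapiens) for inhibition, read by WST assay, with a stated time of 48 h (a higher number here means a weaker inhibitor, a lower number a stronger inhibitor), 115000 nM, the highest of the three numbers measured. Compound 1 `Oc1ccc(/C=N\NC(=S)NC2CCCCC2)c(O)c1` gives 56600 nM, and the step of a 2.0-fold higher number from compound 1 to compound 2 (0.31 log units; beyond the scatter) lies beyond the scatter. Compound 3 `S=C(N/N=C\c1cccs1)NC1CCCCC1` gives 58600 nM, within the scatter of compound 2. Compound 4 `CCOc1ccc(/C=N\NC(=S)NC2CCCCC2)cc1` differs from compound 2 by ethyl in place of hydrogen on an oxygen on an aromatic ring. Among the compounds with values here, no measured step exchanges hydrogen for ethyl on an oxygen on an aromatic ring; the only step available, hydrogen in place of hydroxy, was modest and touches a different change. Nothing therefore points to a large shift, and the step of a 1.2-fold lower number from compound 2 to compound 4 (0.06 log units; within the scatter) is expected to stay within the scatter. Compound 4 in this assay is estimated at 100000 nM, between 40000 nM and 250000 nM.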

Compound 4, half-maximal inhibitory concentration: 68200 nM
Compound 4: the middle estimate sits 1.5-fold (0.17 log units) above what was measured; measured number inside the range.
By their numbers in this assay, from the lowest: compounds 1, 3, 4 and 2 (each within the scatter of the next, the first and the last beyond it).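

In this assay, ethyl in place of hydrogen on an oxygen on an aromatic ring gives a 1.7-fold lower number from compound 2 to compound 4 (0.23 log units; within the scatter) and so stays within the scatter. Within the data shown here, this is the first measured step at this oxygen, and it shows that hydroxy to ethoxy here leaves the reading of compound 2 essentially unmoved, which the earlier step at a different place could not show. Nothing available explains this result.

From the compounds shown here alone, whether a longer chain on this oxygen, or an amine in place of this oxygen, would also stay within the scatter of compound 2 remains open. So does whether ethyl on this oxygen would behave the same with the second hydroxy of compound 1 present.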